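Sulfonamide nitrogen swap from compound 3 to compound 4

The source may hold more compounds than are shown below. What is called first, only, known or untested is meant among the compounds shown, and "the series" means these compounds.

Measured compounds:
- compound 1 `CC(=O)OC[C@H]1O[C@@H](n2cc(CN(c3ccccc3)S(C)(=O)=O)nn2)[C@H](OC(C)=O)[C@@H]1OC(C)=O` gives 250000 nM
- compound 2 `CCCCCCN(Cc1cn([C@@H]2O[C@H](COC(C)=O)[C@@H](OC(C)=O)[C@H]2OC(C)=O)nn1)S(C)(=O)=O` gives 225000 nM
- compound 3 `COc1cccc(N(Cc2cn([C@@H]3O[C@H](COC(C)=O)[C@@H](OC(C)=O)[C@H](OC(C)=O)[C@H]3OC(C)=O)nn2)S(C)(=O)=O)c1` gives 220000 nM

All three values come from a functional assay on MDA-MB-231 cells (Homo sapiens) for antiproliferative activity, read by XTT assay, with a stated time of 48 h (on this read-out lower numbers stand for stronger inhibition and higher numbers for weaker inhibition), and they do not separate: compound 3 at 220000 nM lies within the scatter of both compound 1 and compound 2, so no order can be drawn among them.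

Compound 4 `CC(=O)OC[C@H]1O[C@@H](n2cc(CN(c3ccc(C#N)cc3)S(C)(=O)=O)nn2)[C@H](OC(C)=O)[C@@H](OC(C)=O)[C@@H]1OC(C)=O` keeps the core of compound 3 and changes one group: 4-cyanophenyl in place of 3-methoxyphenyl on a sulfonamide nitrogen in words, 4-cyanophenyl in place of 3-methoxyphenyl on a sulfonamide nitrogen.

Among the compounds with values here, the only measured step of this kind is a 1.1-fold lower number from compound 1 to compound 2 (0.05 log units; within the scatter) for hexyl in place of phenyl on a sulfonamide nitrogen, and it lies within the scatter. Within the data shown here, that evidence is indirect, since compound 1 and compound 2 carry a different core from compound 3 and no measured step involves 4-cyanophenyl.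

The expected change is a 1.0-fold lower number from compound 3 to compound 4 (0.02 log units; within the scatter) in this assay and no shift beyond the scatter is expected. For compound 4 the estimated value is 210000 nM with an expected range of 110000 nM to 350000 nM on this read-out.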

Compound 4, half-maximal inhibitory concentration: 215000 nM
Estimate against measurement, compound 4: 1.0-fold (0.01 log units) below, within the range that was stated.
By their numbers in this assay, from the lowest: compounds 4, 3, 2 and 1 (each within the scatter of the next).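

In this assay, 4-cyanophenyl in place of 3-methoxyphenyl on a sulfonamide nitrogen gives a 1.0-fold lower number from compound 3 to compound 4 (0.01 log units; within the scatter) as its step. Within the data shown here, this is the first exchange at this position between two substituted aromatic rings on one core, and it joins the hexyl for phenyl exchange, with a 1.1-fold lower number from compound 1 to compound 2 (0.05 log units; within the scatter), as a second step that stays within the scatter, so neither exchange at this nitrogen separates the compounds on this read-out. Nothing measured here offers an explanation for this flat result.

Open, as far as these compounds go, is whether an amine, a carboxylic acid or a chain longer than hexyl on a sulfonamide nitrogen would move the number in this assay beyond the scatter. Also open, from the compounds shown here alone, is whether a free hydroxyl in place of the acetate esters on the shared core would do so.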